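The source may hold more compounds than are shown below. What is called first, only, known or untested is meant among the compounds shown, and "the series" means these compounds.

Values measured in an ADME assay on HepG2 cells (Homo sapiens) for cytotoxicity, read by neutral red uptake, with a stated time of 24 h; a higher number here means a weaker inhibitor, a lower number a stronger inhibitor:

- compound 1 `CC(=O)Oc1c(C(C)C)cc2c3c1OC(=O)[C@@]31CCCC(C)(C)[C@@H]1CC2`: 294000 nM
- compound 2 `CC(C)C(=O)Oc1c(C(C)C)cc2c3c1OC(=O)[C@@]31CCCC(C)(C)[C@@H]1CC2`: 112000 nM
- compound 3 `CCCCC/C=C/C/C=C/CCCCCCCC(=O)Oc1c(C(C)C)cc2c3c1OC(=O)[C@@]31CCCC(C)(C)[C@@H]1CC2`: 289000 nM

These compounds share a core and differ in the group on one carbonyl carbon. At 112000 nM, compound 2 has the lowest of the three numbers, and in this test a lower number means a stronger effect on the cells. Both other compounds sit clearly higher.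

The next compound to be tested is compound 4 `CC(C)c1cc2c3c(c1OC(=O)c1ccccc1)OC(=O)[C@@]31CCCC(C)(C)[C@@H]1CC2`. Compared with compound 2, the change is phenyl in place of isopropyl on a carbonyl carbon, so that (isopropylcarbonyl)oxy becomes benzoyloxy.

Going by the values given here, only one measured step changes a single group at this carbon: a 2.6-fold lower number from compound 1 to compound 2 (0.42 log units; beyond the scatter). It is modest, and it replaces methyl with isopropyl. A larger group does not always give a lower number, however: compound 3, with its long chain, goes against that idea at 289000 nM. Among the compounds with values here, no measured compound has a phenyl at this carbon, so the direction is uncertain.

A value within the measured range seems the safest expectation, which points to a small rise from the lowest number. The expected change is a 1.5-fold higher number from compound 2 to compound 4 (0.18 log units; within the scatter). For compound 4 the estimated value is 170000 nM, with an expected range of 80000 nM to 350000 nM.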

Compound 4, half-maximal inhibitory concentration: 510000 nM
The estimate for compound 4 lay 3.0-fold (0.48 log units) below the measured number; the whole stated range lies below it.
By their numbers in this assay, from the lowest: compound 2; then compounds 3, 1 and 4 (each within the scatter of the next).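

In this assay, phenyl in place of isopropyl on this carbonyl carbon gives a 4.6-fold higher number from compound 2 to compound 4 (0.66 log units; beyond the scatter), so the low number of compound 2 does not carry over to this ring, even though both groups are free of hydrogen-bond donors and acceptors. Phenyl in place of methyl gives a 1.7-fold higher number from compound 1 to compound 4 (0.24 log units; within the scatter), a difference within the usual scatter, so compound 1 and compound 4 cannot be told apart here. Heavy-atom count alone therefore does not order these numbers: going from methyl to isopropyl comes with a lower number, yet the larger phenyl of compound 4 ends up level with the methyl of compound 1, and among the four compounds only compound 2 stands clearly apart.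

As far as these compounds go, it remains open whether the low number belongs to branching or to isopropyl itself, which a tert-butyl or cyclopropyl group on this carbonyl carbon could help to settle, and whether a phenyl ring carrying an amine or a carboxylic acid would stay level with compound 4. Nothing shown here explains why isopropyl and phenyl differ at this carbon.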